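A few compounds are considered here, and "the series" means these few. Any claim that something is new, unique, unknown or untested is made for them only; others in the source may bear on it.

Compound 1 `COc1cc(C(=O)/C=C/c2c[nH]c3ccccc23)cc(SC)c1OC` and compound 3 `COc1cc(C(=O)/C=C/c2cn(C)c3ccccc23)cc(SC)c1OC` share a core and differ in one place: methyl in place of hydrogen on an aromatic nitrogen. In a functional assay on A2780 cells (Homo sapiens) for antiproliferative activity, read by MTT assay, with a stated time of 48 h (on this read-out higher numbers stand for weaker inhibition and lower numbers for stronger inhibition), compound 1 gives 169 nM, while compound 3 gives 193 nM; the step is a 1.1-fold higher number from compound 1 to compound 3 (0.06 log units; within the scatter), so the added methyl leaves the result essentially unchanged here.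

Compound 2 `COc1cc(C(=O)/C(C)=C/c2c[nH]c3ccccc23)cc([Se]C)c1OC` has a different core; how it differs from compound 1 is not broken down here. In this assay compound 2 gives 25 nM, the lowest of the three numbers, and the gap to compound 1 and to compound 3 lies beyond the scatter.

Compound 4 `COc1cc(C(=O)/C(C)=C/c2cn(C)c3ccccc23)cc([Se]C)c1OC` has not yet been measured. It stands to compound 2 as compound 3 stands to compound 1: methyl in place of hydrogen on an aromatic nitrogen, the same change at the same place. Because the step of a 1.1-fold higher number from compound 1 to compound 3 (0.06 log units; within the scatter) stayed within the scatter, the step from compound 2 to compound 4 is expected to be small too, about a 1.1-fold higher number from compound 2 to compound 4 (0.05 log units; within the scatter). The result for compound 4 in this assay is therefore estimated at 28 nM, most likely between 12 nM and 65 nM, resting only on this single earlier pair.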

Compound 4, half-maximal inhibitory concentration: 35 nM
For compound 4 the middle estimate is 1.3-fold (0.10 log units) below the measured one; measured number inside the range.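

In this assay the methyl in place of hydrogen on an aromatic nitrogen gives a 1.4-fold higher number from compound 2 to compound 4 (0.15 log units; within the scatter) on the core of compound 2, so here too the change leaves the result essentially unchanged. Set side by side, the two steps agree: the same change on two cores in this assay, a 1.1-fold higher number (0.06 log units; within the scatter) from compound 1 to compound 3 and a 1.4-fold higher number (0.15 log units; within the scatter) from compound 2 to compound 4, 1.2-fold (0.09 log units) apart, within the scatter of two such steps. For the compounds shown here, this shows that the change carries over between these two cores with little effect on the number, but it rests on only two pairs and does not show that the same would hold on any other core, nor does it explain why the number stays put.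

The compounds shown carry only hydrogen or methyl on that nitrogen, so it stays open what an ethyl, a longer chain, or a chain ending in an amine or a carboxylic acid would do at the same place. Also open, going by these compounds, is whether the step stays this small in any read-out other than this assay for these compounds.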